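This account rests on a few compounds, and the source may have more. Where it says the series, first, only, none or still open, it means among the compounds named here.

Compound 1 `CCCn1c(=O)c2nc([C@H]3CC4C=CC3C4)[nH]c2n(CCC)c1=O` is a xanthine core carrying a bridged bicyclic group on the aromatic carbon between two ring nitrogen atoms. In an assay on cell membranes for binding affinity to adenosine receptor A1 (Cavia porcellus), read by radioligand binding (on this read-out higher numbers stand for weaker inhibition and lower numbers for stronger inhibition), compound 1 gives 3.4 nM, the lowest of the two numbers measured here. Compound 2 `CC(C)(C)CNc1ncnc2c1ncn2C1O[C@H](CO)[C@@H](O)[C@H]1O`, a nucleoside of a quite different build, gives 17 nM in this assay, a gap from compound 1 that lies beyond the usual scatter. Compound 3 `CCCn1c(=O)c2nc(-c3cc4ccccc4s3)[nH]c2n(CCC)c1=O`, in which a fused aromatic group replaces the bicyclic one, reaches only a limit of the assay, > 100000 nM, and the limit of > 100000 nM in this assay, at which 1 of the 3 values shown sits, marks that limit.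

Among the compounds with values here, compound 4 `CCCn1c(=O)c2nc([C@@H]3CC4CCC3C4)[nH]c2n(CCC)c1=O` differs from compound 1 by a group of 7 heavy atoms (7 carbon; 2 five-membered non-aromatic rings of carbon only) in place of a group of 7 heavy atoms (7 carbon; 2 five-membered non-aromatic rings of carbon only), on an aromatic carbon; the only real change is that the one double bond outside aromatic rings is gone, leaving the saturated bicyclic group. Within the data shown here, no measured pair shows this exact change, so the step from compound 1 to compound 4 is expected to be small, about a 1.2-fold higher number from compound 1 to compound 4 (0.07 log units; within the scatter), with no clear direction beyond the scatter. Compound 4 is therefore estimated at 4 nM, in a range from 1.5 nM to 12 nM.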

Compound 4, inhibition constant: 3.8 nM
The estimate for compound 4 lay 1.1-fold (0.02 log units) above the measured number; low and high end bracket the measured number.
By their numbers in this assay, from the lowest: compounds 1 and 4 (each within the scatter of the next); then compound 2. At a limit, above all of these: compound 3.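

In this assay the loss of the one double bond outside aromatic rings gives a 1.1-fold higher number from compound 1 to compound 4 (0.05 log units; within the scatter), so at this place, the aromatic carbon between two ring nitrogen atoms, the unsaturated and saturated bicyclic groups cannot be told apart. Within the data shown here, the double bond is therefore not needed for a number this low on the shared core, something the earlier compounds could not show, since none of them differed only within this bicyclic group. Nothing measured here offers an explanation for this lack of a clear difference.

The compounds shown leave open how a smaller, single-ring group such as cyclopentyl would compare at this place. They also leave open whether an added hydroxyl group or amine on the saturated bicyclic group would move the number beyond the scatter.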